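This account rests on a few compounds, and the source may have more. Where it says the series, first, only, none or still open, it means among the compounds named here.

Compound 1 `CCCC(=O)OCSc1ccccc1C(=O)NCCCNC(C)=O` gives 21.1 uM in an ADME assay on CEM-SS cells (Homo sapiens) for cytotoxicity, read by XTT assay, with a stated time of 6 days; a higher number here means that more compound is tolerated, a lower number that less compound is tolerated.
Compound 2 `CCCC(=O)OCSc1ccccc1C(=O)NCCCCNC(C)=O` gives 17.4 uM in this assay.
Compound 3 `CCCC(=O)OCSc1ccccc1C(=O)OCC(N)=O` gives 82.1 uM in this assay.

Compound 3 stands highest of the three in this assay: the step of a 3.9-fold higher number from compound 1 to compound 3 (0.59 log units; beyond the scatter) lies beyond the scatter, and compound 2 sits still further from it, while compounds 1 and 2 differ only by a 1.2-fold lower number from compound 1 to compound 2 (0.08 log units; within the scatter). Compound 4 `CCCC(=O)OCSc1ccccc1C(=O)NCC(=O)NC(C)C` differs from compound 3 by ((isopropylcarbamoyl)methyl)amino in place of carbamoylmethoxy on a carbonyl carbon. Within the data shown here, the only measured step that bears on this is a 3.9-fold higher number from compound 1 to compound 3 (0.59 log units; beyond the scatter), which exchanged an amino-type group on that carbonyl carbon for carbamoylmethoxy. Compound 4 returns to an amino-type group there, as in compounds 1 and 2, so a modest step back downward is expected, a 2.7-fold lower number from compound 3 to compound 4 (0.44 log units; beyond the scatter). Compound 4 is therefore estimated at about 30 uM, between 12 uM and 75 uM.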

Compound 4, half-maximal toxic concentration: 92 uM
The estimate for compound 4 lay 3.1-fold (0.49 log units) below the measured number; the whole stated range lies below it.
By their numbers in this assay, from the lowest: compounds 2 and 1 (each within the scatter of the next); then compounds 3 and 4 (each within the scatter of the next).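

Placing ((isopropylcarbamoyl)methyl)amino instead of carbamoylmethoxy on the carbonyl carbon leaves the number unchanged within the scatter (a 1.1-fold higher number from compound 3 to compound 4 (0.05 log units; within the scatter)), so an amino-type group at this place does not by itself go with a lower number. Among the compounds with an amide-type nitrogen, the chain on that nitrogen matters: isopropylcarbamoyl gives higher numbers than 2-acetamidoethyl (a 4.4-fold higher number from compound 1 to compound 4 (0.64 log units; beyond the scatter)) and 3-acetamidopropyl (a 5.3-fold higher number from compound 2 to compound 4 (0.72 log units; beyond the scatter)). Nothing at hand explains these steps. From the compounds shown here alone, whether a carboxylic acid or a free amine at the end of this chain would give a similar number remains open.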